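Lengthening the Amine Side Chain: Expected Lipophilicity of Compound 4

The source may hold more compounds than are shown below. What is called first, only, known or untested is meant among the compounds shown, and "the series" means these compounds.

Of the compounds shown here, three of the shared core have been measured in a physicochemical assay for lipophilicity, using the shake flask method, measured as octanol-water partition, at pH 7.4; on this read-out lower numbers stand for lower lipophilicity and higher numbers for higher lipophilicity. Compound 1 `CN(C)CCCOc1ccc(C(=O)/C=C/c2ccccc2)cc1` gives 1.59. Compound 2 `CCCN(CCC)CCCOc1ccc(C(=O)/C=C/c2ccccc2)cc1` gives 1.91. Compound 3 `CCN(CC)CCCCOc1ccc(C(=O)/C=C/c2ccccc2)cc1` gives 1.74, the second highest of the three numbers, sitting within the scatter of both others: a number 0.15 log units higher from compound 1 to compound 3 (within the scatter) and a number 0.17 log units lower from compound 2 to compound 3 (within the scatter). Within the data shown here, the one step beyond the scatter is a number 0.32 log units higher from compound 1 to compound 2 (beyond the scatter), where the amine grows by four carbons.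

Compound 4 `CCCCN(CCCC)CCCCCOc1ccc(C(=O)/C=C/c2ccccc2)cc1` awaits measurement in this assay. The change from compound 3 is (dibutylamino)methyl in place of diethylamino on a saturated chain carbon, four bonds along the chain from an oxygen on an aromatic ring. Both earlier steps that enlarge the amine bear on it: the larger one, a number 0.32 log units higher from compound 1 to compound 2 (beyond the scatter), came with four added carbons, the smaller, a number 0.15 log units higher from compound 1 to compound 3 (within the scatter), with three. The present change brings in five more heavy atoms than it removes, more than either earlier step, so an upward step beyond the scatter is expected, estimated at a number 0.46 log units higher from compound 3 to compound 4 (beyond the scatter). Compound 4 is therefore expected to give about 2.2, estimated between 1.8 and 2.7.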

Compound 4, partition coefficient: 2.14
For compound 4 the middle estimate is 0.06 log units above the measured one, within the range that was stated.
By their numbers in this assay, from the lowest: compounds 1, 3, 2 and 4 (each within the scatter of the next, the first and the last beyond it).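

In this assay, (dibutylamino)methyl in place of diethylamino, four bonds along the chain from an oxygen on an aromatic ring, gives a number 0.40 log units higher from compound 3 to compound 4 (beyond the scatter). This is the second step beyond the scatter, alongside a number 0.32 log units higher from compound 1 to compound 2 (beyond the scatter), and both bring in more carbon than they remove, though a number 0.15 log units higher from compound 1 to compound 3 (within the scatter) also adds carbon and goes against any simple link between added carbon and a step beyond the scatter. No measurement at hand bears on the origin of this step.

Going by these compounds, compound 4 carries longer groups on the amine and a longer chain to the oxygen together, and the share of each in the step stays open. Also open, on these data alone, is how a cyclic amine such as piperidine or morpholine would read at this place.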